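Chloro on the Phenyl Ring of an Endothelin Receptor Ligand

This account rests on a few compounds, and the source may have more. Where it says the series, first, only, none or still open, it means among the compounds named here.

Measured compounds:
Compound 1 `N#Cc1ccc(OCc2ccsc2)cc1/C=C(/CCC(=O)O)c1ccccc1` gives 700 nM in an assay on A10 cells for binding affinity to Endothelin-1 receptor (Rattus norvegicus); on this read-out lower numbers stand for stronger inhibition and higher numbers for weaker inhibition.
Compound 2 `Cc1ccccc1/C(=C\c1cc(OCc2ccsc2)ccc1Br)C(=O)O` gives 3000 nM in this assay.
Compound 3 `N#Cc1ccc(OCc2ccsc2)cc1/C=C(/C(=O)O)c1ccccc1` gives 80 nM in this assay.

Among the three, compound 3 has the lowest number in this assay, meaning the strongest inhibition found here. Within the data shown here, the one single-point step measured so far is an 8.8-fold lower number from compound 1 to compound 3 (0.94 log units; beyond the scatter), a modest gain that comes from shortening the acid-bearing chain, not from touching the phenyl ring. Compound 2 carries a methyl on its phenyl ring but differs from compound 3 in several other places as well, so its number says little on its own about a ring substituent.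

Compound 4 `N#Cc1ccc(OCc2ccsc2)cc1/C=C(/C(=O)O)c1ccccc1Cl` is compound 3 with chloro in place of hydrogen on an aromatic carbon. Among the measured compounds shown here, no measured step bears directly on this change. With nothing to point either way, the expected outcome in this assay is a step of no change at the digits printed from compound 3 to compound 4 (within the scatter), that is, none beyond the scatter. Compound 4 is therefore expected to give about 80 nM, within a range of 25 nM to 250 nM.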

Compound 4, half-maximal inhibitory concentration: 200 nM
For compound 4 the middle estimate is 2.5-fold (0.40 log units) below the measured one; low and high end bracket the measured number.
By their numbers in this assay, from the lowest: compound 3; then compound 4; then compound 1; then compound 2.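

In this assay, among these compounds, going from phenyl to 2-chlorophenyl gives a 2.5-fold higher number from compound 3 to compound 4 (0.40 log units; beyond the scatter), the first direct reading at this place on the ring, as the earlier single-point step concerned only the acid-bearing chain. The step is modest but beyond the scatter, so this aromatic carbon, ortho to a large group, is not indifferent to substitution: adding a single chlorine atom here gives a weaker result than hydrogen. Nothing in the data shown explains this rise in the number.

Still open, as far as these compounds go, is whether the loss is particular to chloro, or whether fluoro or methoxy on the same carbon would move the number as far or further. Also open, from the compounds shown here alone, is whether chloro would have the same effect in the compound carrying the longer 2-carboxyethyl chain, compound 1.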